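Methoxy added to the ring on the aromatic nitrogen

This account rests on a few compounds, and the source may have more. Where it says the series, first, only, none or still open, it means among the compounds named here.

Working notes on the series; all values come from a functional assay on A549 cells (Homo sapiens) for inhibition, read by MTT assay, with a stated time of 48 h; on this read-out lower numbers stand for stronger inhibition and higher numbers for weaker inhibition.

- compound 1 `COc1ccc(-n2cc(NC(=O)c3cccc(NS(=O)(=O)c4ccc(Cl)cc4)c3)cn2)cc1`: compound 1 gives 29700 nM
- compound 2 `Cn1cc(NC(=O)c2ccc(NS(=O)(=O)c3ccccc3)cc2)cn1`: compound 2 reports only the limit > 100000 nM
- compound 3 `O=C(Nc1cnn(-c2ccccc2)c1)c1ccc(NS(=O)(=O)c2ccccc2)cc1`: compound 3 gives 87100 nM

Compound 3 holds the highest of the two numbers available in this assay; the nearest number belongs to compound 1, and that gap lies beyond the usual scatter. Compound 2 is known only as a limit of this assay (the limit of > 100000 nM in this assay, at which 1 of the 3 values shown sits).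

Compound 4 `COc1cccc(-n2cc(NC(=O)c3ccc(NS(=O)(=O)c4ccccc4)cc3)cn2)c1` is the next member. It differs from compound 3 by methoxy in place of hydrogen on an aromatic carbon.

Within the data shown here, only one single-place step has been measured so far: an at least 1.1-fold lower number from compound 2 to compound 3 (0.05 log units; that floor lies within the scatter). That step exchanges the whole group on the aromatic nitrogen and lies within the scatter, so it says nothing direct about a methoxy placed on that ring. Compound 1 also carries a methoxyphenyl on its aromatic nitrogen, yet it differs from compound 3 in several further places, so its lower number cannot be tied to the methoxy alone.

Among the measured compounds shown here, with no step that bears on this change, no movement beyond the scatter is expected for compound 4, and the step of a 1.2-fold lower number from compound 3 to compound 4 (0.09 log units; within the scatter) is the estimate. Compound 4 is therefore expected to give about 70000 nM, with a range from 30000 nM to 140000 nM, and a real chance that this assay returns only a limit for compound 4.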

Compound 4, half-maximal inhibitory concentration: > 100000 nM
Compound 4 ended at the assay's limit; the forecaster's own chance of this, stated with the estimate: 30%; middle value at least 1.4-fold (0.15 log units) from the limit.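

Among these compounds, the first single-place step on the ring carried by the aromatic nitrogen gives an at least 1.1-fold higher number from compound 3 to compound 4 (0.05 log units; that floor lies within the scatter) in this assay, so the change from phenyl to 3-methoxyphenyl brings no measurable gain in inhibition on this core. Compound 4 is known only as a limit, so the step has a floor and no upper end, and its true size could lie within the scatter or beyond it. The step from compound 2 to compound 4 cannot be read, because both values are limits: the limit of > 100000 nM in this assay, at which 2 of the 4 values shown sit.

From the compounds shown here alone, what an amine or a carboxylic acid would do in place of the methoxy at this place on the six-membered aromatic ring stays open, since a single methoxy step at the weak end of the read-out says little about other groups there. Also open, going by these compounds, is whether methoxy matters on the core of compound 1, which gives 29700 nM, a number that still leaves room for a step in either direction.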